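Adding a phenyl to the amide arm of a benzothiazole thioether

This account rests on a few compounds, and the source may have more. Where it says the series, first, only, none or still open, it means among the compounds named here.

Measured so far:
compound 1, `CC(=O)Nc1ccc2nc(SCC(=O)NCc3ccccc3)sc2c1`, gives 17600 nM in a functional assay on MCF7 cells (Homo sapiens) for cytotoxicity, read by MTT assay, with a stated time of 48 h; on this read-out lower numbers stand for stronger inhibition and higher numbers for weaker inhibition
compound 2, `CNC(=O)CSc1nc2ccc(NC(=O)c3ccc(Cl)cc3)cc2s1`, gives 29400 nM in this assay

Compound 2 has the larger of the two numbers, but the gap to compound 1 is within the usual scatter, so the two cannot be told apart on these data.

Compound 3, `O=C(CSc1nc2ccc(NC(=O)c3ccc(Cl)cc3)cc2s1)NCc1ccccc1`, differs from compound 2 in one place: phenyl in place of hydrogen on a saturated chain carbon bound to an amide-type nitrogen. Among the measured compounds shown here, no step between measured compounds is available to calibrate this change. Compound 1 carries the same benzylcarbamoyl group, paired with a different cap, and its number is not separated from that of compound 2, so only a small shift in this assay is expected for compound 3, perhaps toward a lower number but possibly none beyond the scatter, giving an expected step of a 1.8-fold lower number from compound 2 to compound 3 (0.26 log units; within the scatter). For compound 3 the estimate is 16000 nM, with a range from 5000 nM to 45000 nM.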

Compound 3, half-maximal inhibitory concentration: 25900 nM
For compound 3 the middle estimate is 1.6-fold (0.21 log units) below the measured one; the measured number falls inside the stated range.
By their numbers in this assay, from the lowest: compounds 1, 3 and 2 (each within the scatter of the next).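

Methyl to benzyl on the amide arm now has its first direct reading: in this assay the change gives a 1.1-fold lower number from compound 2 to compound 3 (0.06 log units; within the scatter) and so does not separate the two compounds. The second new comparison, 4-chlorophenyl in place of methyl on a carbonyl carbon, keeps the benzylcarbamoyl group fixed and gives a 1.5-fold higher number from compound 1 to compound 3 (0.17 log units; within the scatter) as its reading, which also leaves the pair unresolved. Both single changes therefore stay inside the scatter for these compounds, and nothing available here explains these readings.

From the compounds shown here alone, it remains open whether a different group on this amide nitrogen, such as a longer chain ending in phenyl, an amine or a carboxylic acid, would give a number clearly apart from these. The compounds shown also cannot say whether a substituent on the new phenyl ring would matter.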